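A few compounds are considered here, and "the series" means these few. Any claim that something is new, unique, unknown or untested is made for them only; others in the source may bear on it.

Of the compounds shown here, three built on one shared core have been tested in a functional assay on K562 cells (Homo sapiens) for inhibition, read by sulforhodamine B assay, with a stated time of 48 h; a lower number here means a stronger inhibitor of growth, a higher number a weaker inhibitor of growth. Compound 1 `Nc1cc(N)c2nc(-c3ccccc3)c(NCc3ccc(Cl)c(Cl)c3)nc2c1` gives 3090 nM, compound 2 `COc1ccc(CNc2nc3cc(N)cc(N)c3nc2-c2ccccc2)cc1OC` gives 6030 nM, and compound 3 `Nc1cc(N)c2nc(-c3ccccc3)c(NCc3ccc(F)cc3)nc2c1` gives 4370 nM, the second highest of the three numbers, with its steps to both others within the scatter. Compound 4 `COc1ccc(CNc2nc3cc(N)cc(N)c3nc2-c2ccccc2)cc1` differs from compound 3 by methoxy in place of fluoro on an aromatic carbon. Among the measured compounds shown here, the steps that bear on this change are the earlier swaps on the same benzyl ring: a 1.4-fold higher number from compound 1 to compound 3 (0.15 log units; within the scatter) and a 1.4-fold lower number from compound 2 to compound 3 (0.14 log units; within the scatter), while a 2.0-fold higher number from compound 1 to compound 2 (0.29 log units; within the scatter) also stayed within the scatter. Each change of this substituent so far has left the number essentially unchanged, so no step beyond the scatter is expected. The expected step is a 1.0-fold higher number from compound 3 to compound 4 (0.01 log units; within the scatter). Compound 4 is therefore estimated at 4500 nM, within a range from 2000 nM to 10000 nM.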

Compound 4, concentration for 50% growth inhibition: 25100 nM
Compound 4: middle estimate off by 5.6-fold (0.75 log units), on the low side, outside the stated range (above it).
By their numbers in this assay, from the lowest: compounds 1, 3 and 2 (each within the scatter of the next); then compound 4.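

In this assay, the benzyl ring proves sensitive to a single substituent, with a 5.7-fold higher number from compound 3 to compound 4 (0.76 log units; beyond the scatter). Adding hydrogen in place of one methoxy also weakens growth inhibition, giving a 4.2-fold higher number from compound 2 to compound 4 (0.62 log units; beyond the scatter), and the distance from the dichloro compound is larger still, at an 8.1-fold higher number from compound 1 to compound 4 (0.91 log units; beyond the scatter). The 4-methoxyphenyl group thus stands apart from the 4-fluorophenyl, 3,4-dimethoxyphenyl and 3,4-dichlorophenyl groups, whose numbers all lie within the scatter of one another.

Nothing available explains why a lone methoxy differs in this way. From the compounds shown here alone, whether an amine or a carboxylic acid at this place would track with fluoro or with methoxy remains open.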